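Series notes: the step from compound 2 to compound 4

The source may report more compounds than this note shows. Statements on the series, on what has been measured and on what is new or still open speak of the compounds shown alone.

All three measured compounds share one core and differ only in the group carried on the oxygen on the aromatic ring; the read-out throughout is a functional assay on PANC-1 cells (Homo sapiens) for inhibition, read by MTT assay, with a stated time of 24 h, tested at 10 uM; a higher number here means more inhibition at the concentration tested (going by the name of the read-out), a lower number less inhibition. Compound 1 `CC(C)=CCC/C(C)=C/CC1Cc2c(OCCCNS(=O)(=O)c3ccc(Cl)cc3)cc(=O)n(CCCO)c2CC1(C)C` gives 16.1%. Compound 2 `CC(C)=CCC/C(C)=C/CC1Cc2c(OCCCNC(=O)c3ccco3)cc(=O)n(CCCO)c2CC1(C)C` gives 2.8% and stands lowest of the three measured numbers. Compound 3 `CC(C)=CCC/C(C)=C/CC1Cc2c(OCCCNC(=O)c3ccc([N+](=O)[O-])cc3)cc(=O)n(CCCO)c2CC1(C)C` gives 6.5%. The step of a number 13.3 percentage points lower from compound 1 to compound 2 (beyond the scatter) lies beyond the scatter, whereas a number 9.6 percentage points lower from compound 1 to compound 3 (within the scatter) and a number 3.7 percentage points higher from compound 2 to compound 3 (within the scatter) both lie within it, so compound 2 and compound 3 cannot be ordered against each other.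

Going by the values given here, compound 4 `COc1ccccc1NC(=O)Oc1cc(=O)n(CCCO)c2c1CC(C/C=C(\C)CCC=C(C)C)C(C)(C)C2` is not yet measured. (2-methoxyphenyl)carbamoyl in place of 3-(((furan-2-yl)carbonyl)amino)propyl on an oxygen on an aromatic ring Each of the measured steps exchanges only the group on the amine nitrogen at the far end of the chain that now leaves; none touches the oxygen on the aromatic ring directly, so no measured step covers this change. They bear on it only in showing that the whole variation seen so far across the three compounds spans a modest range, with compound 2 at the bottom of it. No step beyond the scatter is therefore expected in this assay, in either direction. For compound 4 the estimate is 8%, with a range from 0% to 25%. The step this estimate means is expected to be a number 5.2 percentage points higher from compound 2 to compound 4 (within the scatter).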

Compound 4, a percentage reported as inhibition, at one concentration (the size of the read-out at that concentration, not a potency): 0%
For compound 4 the middle estimate is 8 percentage points above the measured one, and the stated range covers the measured number.
By their numbers in this assay, from the lowest: compounds 4, 2, 3 and 1 (each within the scatter of the next, the first and the last beyond it).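

Going by these compounds alone, this is the first change that replaces the whole group on the oxygen on the aromatic ring, not just the end of its chain, and in this assay it gives a number 2.8 percentage points lower from compound 2 to compound 4 (within the scatter), a step that leaves compound 2 and compound 4 indistinguishable. The two groups match in their counted heavy atoms, hydrogen-bond donors and hydrogen-bond acceptors, yet the (2-methoxyphenyl)carbamoyl group carries a six-membered aromatic ring of carbon only where the 3-(((furan-2-yl)carbonyl)amino)propyl group carries a five-membered one, and at this single concentration that exchange produces no readable change from a starting number that was already low. No measurement available here accounts for this result.

What the compounds shown leave open is whether the (2-methoxyphenyl)carbamoyl group would also make no readable difference when set against a compound with a higher number in this assay, such as one keeping the (4-chlorophenyl)sulfonyl group on the chain. Also open, from the compounds shown here alone, is whether a free amine, a carboxylic acid or a longer chain on this oxygen would move the number beyond the scatter.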